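The source may report more compounds than this note shows. Statements on the series, on what has been measured and on what is new or still open speak of the compounds shown alone.

Measured compounds and their numbers in a functional assay on HeLa cells (Homo sapiens) for antiproliferative activity, read by sulforhodamine B assay, with a stated time of 72 h; a lower number here means a stronger inhibitor, a higher number a weaker inhibitor:

Compound 1 `Fc1cccc(NC(=S)N/N=C/c2ccc3ccccc3n2)c1` gives 70100 nM.
Compound 2 `COc1cccc(NC(=S)N/N=C/c2ccc3ccccc3n2)c1` gives 74500 nM.
Compound 3 `S=C(N/N=C/c1ccc2ccccc2n1)Nc1cccc(Br)c1` gives 70000 nM.

Compound 3 holds the lowest of the three numbers, but the three sit within the scatter of one another, so no ordering among them can be read. The three steps that connect them, a 1.1-fold higher number from compound 1 to compound 2 (0.03 log units; within the scatter), a 1.0-fold lower number from compound 1 to compound 3 (0.00 log units; within the scatter) and a 1.1-fold lower number from compound 2 to compound 3 (0.03 log units; within the scatter), all lie within the scatter: exchanging fluoro, methoxy and bromo on the aromatic carbon moved nothing that can be distinguished from repeat measurement.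

For the measured compounds named here, compound 4 `S=C(N/N=C/c1ccc2ccccc2n1)Nc1ccc(Cl)cc1` has not yet been measured. 4-chlorophenyl in place of 3-bromophenyl on an amide-type nitrogen This change differs from the measured ones in that both the halogen and the position of the substituent on the phenyl change, so no step bears on it exactly. The nearest guide is a 1.0-fold lower number from compound 1 to compound 3 (0.00 log units; within the scatter), a swap of one halogen for another without effect, which suggests the chloro itself will do little. Going by the values given here, the shift of position has no precedent here. Compound 4 is therefore expected to stay close to compound 3, with a 1.0-fold higher number from compound 3 to compound 4 (0.01 log units; within the scatter), estimated at 72000 nM with a range of 35000 nM to 150000 nM.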

Compound 4, half-maximal inhibitory concentration: > 100000 nM
Compound 4: a limit, no number; the forecaster's own chance of this, stated with the estimate: 15%; middle value at least 1.3-fold (0.14 log units) from the limit.
By their numbers in this assay, from the lowest: compounds 3, 1 and 2 (each within the scatter of the next). At a limit, above all of these: compound 4.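

Compound 4 is recorded in this assay only as a limit, not as a number: the limit of > 100000 nM in this assay, at which 1 of the 4 values shown sits. The steps to it are an at least 1.4-fold higher number from compound 3 to compound 4 (0.15 log units; that floor lies within the scatter), an at least 1.3-fold higher number from compound 2 to compound 4 (0.12 log units; that floor lies within the scatter) and an at least 1.4-fold higher number from compound 1 to compound 4 (0.15 log units; that floor lies within the scatter), so each gives only a floor, and none of these floors separates compound 4 from the others beyond the scatter. Even so, 4-chlorophenyl on the amide-type nitrogen is the first group here to give no number, whereas the 3-fluorophenyl, 3-methoxyphenyl and 3-bromophenyl groups all gave one.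

The halogen and its place on the phenyl ring change together, so the compounds shown cannot tell which of the two matters, and how far compound 4 truly lies from the others stays unknown. A 3-chlorophenyl or 4-bromophenyl group would separate the two, and a 4-aminophenyl or 4-carboxyphenyl group would test that place with a different kind of substituent.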